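This account rests on a few compounds, and the source may have more. Where it says the series, first, only, none or still open, it means among the compounds named here.

Working notes on the series.

Of the compounds shown here, three share the core and have been measured in an assay on isolated protein for inhibition of phosphatidylinositol 4,5-bisphosphate 3-kinase catalytic subunit beta isoform (Homo sapiens); a lower number here means a stronger inhibitor, a higher number a weaker inhibitor. Compound 1 `COc1ccc(-c2ccnc(Nc3ccc(Cl)cc3Cl)n2)cc1` gives 839 nM. Compound 2 `COc1cccc(Nc2nccc(-c3ccc(Cl)c(Cl)c3)n2)c1` gives 741 nM. Compound 3 `Cc1cccc(Nc2nccc(-c3ccc(Cl)cc3Cl)n2)c1` gives 851 nM. Among these three numbers compound 1 has the second highest; its nearest neighbour is compound 3 and its furthest is compound 2, and both gaps lie within the scatter, so the three values show no difference that can be read as order.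

Compound 4 `COc1ccc(-c2ccnc(Nc3ccc(Cl)cc3)n2)cc1` has not been measured in this assay. Relative to compound 1 the change is hydrogen in place of chloro on an aromatic carbon, on an aromatic carbon of a six-membered aromatic ring of carbon only, ortho to a large group and meta to a chloro group. For the measured compounds named here, no step between two measured compounds isolates this change, so its size is not known from the series. The expectation is a modest step toward a higher number, near the edge of the scatter, a 1.8-fold higher number from compound 1 to compound 4 (0.25 log units; within the scatter). Compound 4 is estimated at 1500 nM, with a range from 500 nM to 5000 nM.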

Compound 4, half-maximal inhibitory concentration: 603 nM
The estimate for compound 4 lay 2.5-fold (0.40 log units) above the measured number; low and high end bracket the measured number.
By their numbers in this assay, from the lowest: compounds 4, 2, 1 and 3 (each within the scatter of the next).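

Replacing chloro with hydrogen on an aromatic carbon, ortho to a large group and meta to a chloro group, gives a 1.4-fold lower number from compound 1 to compound 4 (0.14 log units; within the scatter) in this assay. For the compounds shown here, this is the first reading of a single change, and it shows that, on the core of compound 1, loss of this chloro group leaves no difference that can be read from the scatter. No evidence on hand bears on this result.

As far as these compounds go, whether this position tolerates other groups stays open, as an amine, a carboxylic acid or a longer chain in place of the chloro group could behave differently. The remaining chloro group is also untested on its own, and steps to compounds 2 and 3 cannot be read, as they differ from these two in more than one place.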